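Sulfonyl aryl variation on a shared core: growth inhibition

This account rests on a few compounds, and the source may have more. Where it says the series, first, only, none or still open, it means among the compounds named here.

Compound 1 `Cc1cc(C)c(S(=O)(=O)NC2=NCCN2C(=S)SN2CCn3c2nsc3=S)c(C)c1`: in a functional assay on KYSE-510 cells (Homo sapiens) for antiproliferative activity, read by crystal violet staining, with a stated time of 96 h (on this read-out higher numbers stand for weaker inhibition of growth and lower numbers for stronger inhibition of growth), compound 1 gives >= 20000 nM, which is a limit of the assay.
Compound 2 `O=S(=O)(NC1=NCCN1C(=S)SN1CCn2c1nsc2=S)c1ccc(C(F)(F)F)cc1`: in this assay compound 2 gives >= 20000 nM, again a limit.
Compound 3 `CC(=O)Nc1ccc(S(=O)(=O)NC2=NCCN2C(=S)SN2CCn3c2nsc3=S)cc1`: in this assay compound 3 gives >= 20000 nM, also a limit.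

Compound 3 therefore stands at the limit, as do the other two, since (the limit of >= 20000 nM in this assay, at which 3 of the 3 values shown sit). Among the compounds with values here, none of the measured steps can be sized: a step that the two limits leave unreadable from compound 1 to compound 2, a step that the two limits leave unreadable from compound 1 to compound 3 and a step that the two limits leave unreadable from compound 2 to compound 3 are all left unreadable by the limits on both sides.

The next compound is compound 4 `O=S(=O)(NC1=NCCN1C(=S)SN1CCn2c1nsc2=S)c1ccccc1Cl`. It differs from compound 3 by 2-chlorophenyl in place of 4-acetamidophenyl on a sulfonyl sulfur. The two steps that touch the same place, from compound 1 to compound 3 and from compound 2 to compound 3, are both unreadable, so nothing measured gives a direction for this change. The expectation is that compound 4 also sits at the limit, with the step of a number no higher from compound 3 to compound 4 (the limit leaves the size open) expected to be none beyond the scatter. Compound 4 is estimated at 20000 nM, within 8000 nM to 60000 nM, most probably reported as a limit only.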

Compound 4, concentration for 50% growth inhibition: >= 20000 nM
Compound 4 ended at the assay's limit (the forecaster's own chance of this, stated with the estimate: 80%); the middle value lies on the limit itself.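

Within the data shown here, no step from compound 1, compound 2 or compound 3 to compound 4 can be read, because all four compounds sit at the same limit: the limit of >= 20000 nM in this assay, at which 4 of the 4 values shown sit.

The compounds shown leave open whether any aryl group on the sulfonyl sulfur shifts growth inhibition, and in which direction.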